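A few compounds are considered here, and "the series" means these few. Any claim that something is new, unique, unknown or untested is made for them only; others in the source may bear on it.

Of the compounds shown here, two have been measured in a physicochemical assay for lipophilicity, at pH 7.4; a higher number here means a more lipophilic compound, a lower number a more polar compound. Compound 1 (`CCCCC#Cc1c(C)[nH]c2ccccc2c1=O`) gives 5.44 and compound 2 (`COc1cc2[nH]c(C)c(C(C)C)c(=O)c2cc1Cl`) gives 2.84, which makes compound 2 the lower of the two, by a gap beyond the usual scatter. These two compounds differ in more than one place, so their gap cannot be tied to any single change. Compound 3 (`CCCCC/C=C/c1c(C)[nH]c2cc(OC)c(Cl)cc2c1=O`) has not yet been measured. It departs from compound 2 in one place, with hept-1-en-1-yl in place of isopropyl on an aromatic carbon. Among the measured compounds shown here, no measured pair shows this change on its own, so the expectation rests on the size of the new chain and on a single comparison. Compound 1, at 5.44, also carries a long unbranched chain, although the rest of its structure is not the same. A large upward move in this assay is therefore expected, with the estimated step of a number 2.66 log units higher from compound 2 to compound 3 (beyond the scatter) lying well beyond the scatter. The estimate for compound 3 is 5.5, with an expected range from 4.7 to 6.3.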

Compound 3, distribution coefficient: 3.57
Compound 3: middle estimate off by 1.93 log units, on the high side; the whole stated range lies above it.
By their numbers in this assay, from the lowest: compound 2; then compound 3; then compound 1.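

In this assay, hept-1-en-1-yl in place of isopropyl on this aromatic carbon, ortho to a methyl group and two atoms from the ring nitrogen, gives a number 0.73 log units higher from compound 2 to compound 3 (beyond the scatter). Among the compounds shown here, this is the first change at this position that can be read on its own, and it shows that with the rest of the structure held fixed, a chain of 7 heavy atoms with 1 double bond replacing a group of 3 heavy atoms produces a step rated modest, though one that stands beyond the scatter. No measurement in hand accounts for the size of this step.

A single step at a single position leaves open how the number follows chain length and shape: a saturated heptyl chain would separate the part played by the double bond from that of the chain length, and an intermediate butyl or pentyl chain would show whether the number climbs evenly between isopropyl and hept-1-en-1-yl. Also open, going by these compounds, is how the number would respond at this same carbon to a chain that ends in an amine or a carboxylic acid.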